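This account rests on a few compounds, and the source may have more. Where it says the series, first, only, none or still open, it means among the compounds named here.

Measured in an assay on cells for displacement of a labelled ligand from adenosine receptor A1 (Homo sapiens), read by scintillation counting and radioligand binding, with a stated time of 60 min, tested at 10 uM; on this read-out lower numbers stand for less inhibition and higher numbers for more inhibition at the one concentration tested (going by the name of the read-out):

Compound 1 `Cn1cnc2c(N3CCCCC3)nc(-c3cc(Cl)ccc3Cl)nc21` gives 13.2%.
Compound 2 `Clc1ccc(Cl)c(-c2nc(N3CCCCC3)c3nc[nH]c3n2)c1` gives 1.4%.
Compound 3 `Clc1cccc(-c2nc(N3CCCCC3)c3nc[nH]c3n2)c1` gives > 80%, which is a limit of the assay and not a number.

Two single changes connect these three. The change methyl in place of hydrogen on an aromatic nitrogen produces a step of a number 11.8 percentage points higher from compound 2 to compound 1 (beyond the scatter). The change hydrogen in place of chloro on an aromatic carbon produces a step of a number at least 78.6 percentage points higher from compound 2 to compound 3 (beyond the scatter), and here compound 3 sits at the limit (the limit of > 80% in this assay, at which 1 of the 3 values shown sits), so the true size of this step is not known.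

Compound 4 `Cn1cnc2c(N3CCCCC3)nc(-c3cccc(Cl)c3)nc21` has not yet been measured in this assay. For the measured compounds named here, it differs from compound 3 by methyl in place of hydrogen on an aromatic nitrogen, which is the same change as the one from compound 2 to compound 1, made on the same place of the fused ring system; the two cores differ by hydrogen in place of chloro on an aromatic carbon.

Because that earlier change gave a number 11.8 percentage points higher from compound 2 to compound 1 (beyond the scatter), compound 4 is expected to remain at or above the level of compound 3, an expected step that the limit leaves unreadable from compound 3 to compound 4. The estimate for compound 4 in this assay is 88%, between 70% and 98%, most likely reported again only as a limit.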

Compound 4, a percentage reported as inhibition, at one concentration (the size of the read-out at that concentration, not a potency): 22.4%
Beside the measured number, compound 4's estimate is 65.6 percentage points above it; measured number below the stated range.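

In this assay, methyl in place of hydrogen on an aromatic nitrogen gives a number at least 57.6 percentage points lower from compound 3 to compound 4 (beyond the scatter), so the change does not keep its direction when it is carried from the core bearing two chloro groups to the core bearing one: the same change on two cores in this assay, a number 11.8 percentage points higher (beyond the scatter) from compound 2 to compound 1 and a number at least 57.6 percentage points lower (beyond the scatter) from compound 3 to compound 4, at least 69.4 percentage points apart, beyond the scatter of two such steps. As far as these compounds go, compound 3 gives > 80%, which is a limit of the assay and not a number, so the true size of its steps stays unknown. Hydrogen in place of chloro gives a number 9.2 percentage points higher from compound 1 to compound 4 (within the scatter) on the methyl-bearing core, so this step does not transfer between the two cores either, though two pairs of compounds do not show why, or how a third core would behave: the same change on two cores in this assay, a number at least 78.6 percentage points higher (beyond the scatter) from compound 2 to compound 3 and a number 9.2 percentage points higher (within the scatter) from compound 1 to compound 4, at least 69.4 percentage points apart, beyond the scatter of two such steps.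

The compounds shown leave open whether a longer chain on that aromatic nitrogen would follow methyl or hydrogen in this read-out. They also leave open how an amine or a carboxylic acid in place of the remaining chloro would read at this single concentration.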